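The compounds below may be only part of what the source reports. "The series", "measured", "known", "first", "only" and "open" are said of these compounds alone.

Working notes on the series. Compound 1 `CCCCCOC(=O)N1CCN(C(=O)c2nc(Nc3cc(C4CC4)[nH]n3)c3cc(Cl)ccc3n2)C[C@H]1C` and compound 2 `CC(OC(=O)C(C)C)OC(=O)N1CCN(C(=O)c2nc(Nc3cc(C4CC4)[nH]n3)c3cc(Cl)ccc3n2)C[C@H]1C` share one core and differ only in the group on an oxygen next to a carbonyl group. In an assay for inhibition of serine/threonine-protein kinase PAK 4 (Homo sapiens), read by FRET and Z'-LYTE, with a stated time of 60 min, tested at 0.5 uM, in the presence of a further agent that is not named here (on this read-out lower numbers stand for a weaker effect and higher numbers for a stronger effect at the one concentration tested), compound 1 gives -3.8%. In this assay compound 2 gives 9.4%. Going by the values given here, compound 2 stands highest of the two numbers known so far, with compound 1 nearest. Among the compounds with values here, the one measured step at this place is a number 13.2 percentage points higher from compound 1 to compound 2 (beyond the scatter), a modest rise on exchange of pentyl for 1-((isopropylcarbonyl)oxy)ethyl; both numbers remain small at the one concentration tested.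

Compound 3 `C[C@@H]1CN(C(=O)c2nc(Nc3cc(C4CC4)[nH]n3)c3cc(Cl)ccc3n2)CCN1C(=O)OCOC(=O)C(C)(C)C` is not yet measured. It differs from compound 2 by (((tert-butyl)carbonyl)oxy)methyl in place of 1-((isopropylcarbonyl)oxy)ethyl on an oxygen next to a carbonyl group. The two have the same atoms, joined differently, and no measured step tests such a rearrangement; the only step that bears on this place is the modest one given above. The expectation in this assay is therefore no step beyond the scatter, a number 3.4 percentage points lower from compound 2 to compound 3 (within the scatter). Compound 3 is estimated at 6%, with a range from -8% to 20%.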

Compound 3, a percentage reported as inhibition, at one concentration (the size of the read-out at that concentration, not a potency): 0.7%
For compound 3 the middle estimate is 5.3 percentage points above the measured one; measured number inside the range.
By their numbers in this assay, from the lowest: compounds 1, 3 and 2 (each within the scatter of the next, the first and the last beyond it).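

Within this assay, the rearrangement of the same atoms gives a number 8.7 percentage points lower from compound 2 to compound 3 (within the scatter) and so separates neither group from the other at this position on an oxygen next to a carbonyl group. The exchange of butyl for ((tert-butyl)carbonyl)oxy, on a saturated chain carbon bound to an oxygen next to a carbonyl group, gives a number 4.5 percentage points higher from compound 1 to compound 3 (within the scatter) and so places compound 3 within the scatter of both earlier compounds, which means that the rise seen with 1-((isopropylcarbonyl)oxy)ethyl does not recur beyond the scatter with (((tert-butyl)carbonyl)oxy)methyl. No measurement at hand accounts for these numbers.

The three compounds leave open whether an amine, a carboxylic acid or a chain longer than pentyl at this position would move the number further than these groups do, and what hydrogen in place of the whole group on the carbonyl would give on the shared core. With one concentration as the only read-out, the series also leaves open how these compounds would rank in potency.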